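This account rests on a few compounds, and the source may have more. Where it says the series, first, only, none or still open, it means among the compounds named here.

Measured compounds in a functional assay on CCRF-CEM cells for antagonist activity at C-X-C chemokine receptor type 4 (Homo sapiens), read by calcium flux, with stated times of 25 min and 90 s; a lower number here means a stronger inhibitor, a higher number a weaker inhibitor:
- compound 1 `C/C(CN)=C(/F)CN(C[C@H]1Cc2ccccc2CN1)[C@H]1CCCc2cccnc21` gives 44 nM
- compound 2 `C/C(=C/CN(C[C@H]1Cc2ccccc2CN1)[C@H]1CCCc2cccnc21)CN` gives 8.6 nM
- compound 3 `N[C@H]1CC[C@H](N(C[C@H]2Cc3ccccc3CN2)[C@H]2CCCc3cccnc32)CC1` gives 34 nM

Compound 3 stands second highest of the three numbers. Its gap to one neighbour is within the scatter: a 1.3-fold lower number from compound 1 to compound 3 (0.11 log units; within the scatter). Its gap to the other is beyond it: a 4.0-fold higher number from compound 2 to compound 3 (0.60 log units; beyond the scatter).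

Compound 4 `C/C(=C/CN)CN(C[C@H]1Cc2ccccc2CN1)[C@H]1CCCc2cccnc21` is not yet measured. The change from compound 3 is a group of 6 heavy atoms (5 carbon, 1 nitrogen; no ring) in place of a group of 7 heavy atoms (6 carbon, 1 nitrogen; one six-membered non-aromatic ring of carbon only), on an amine nitrogen. The entering chain has the same count of atoms as the chain of compound 2, so compound 4 is an isomer of compound 2 and the step is, in effect, the reverse of the measured one: a 4.0-fold higher number from compound 2 to compound 3 (0.60 log units; beyond the scatter). That the exact make-up of such a chain matters is shown by a 5.1-fold lower number from compound 1 to compound 2 (0.71 log units; beyond the scatter), where a small change moved the number beyond the scatter, so compound 4 need not match compound 2 exactly. A modest lower number is therefore expected for compound 4, most likely between the values of compound 2 and compound 3.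

The step expected is a 2.3-fold lower number from compound 3 to compound 4 (0.36 log units; beyond the scatter). Compound 4 is estimated at 15 nM, with a range from 5 nM to 45 nM.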

Compound 4, half-maximal inhibitory concentration: 28 nM
For compound 4 the middle estimate is 1.9-fold (0.27 log units) below the measured one; low and high end bracket the measured number.
By their numbers in this assay, from the lowest: compound 2; then compounds 4, 3 and 1 (each within the scatter of the next).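

In this assay, the open chain of compound 4 and the 4-aminocyclohexyl group on the amine nitrogen do not separate: a 1.2-fold lower number from compound 3 to compound 4 (0.08 log units; within the scatter). The arrangement of the chain still counts, as two chains of equal atom count differ by a 3.3-fold higher number from compound 2 to compound 4 (0.51 log units; beyond the scatter), while the fluorine-bearing chain stays level with the chain of compound 4, at a 1.6-fold lower number from compound 1 to compound 4 (0.20 log units; within the scatter). No measurement to hand explains these differences.

Still open, from the compounds shown here alone, is how a chain ending in a dimethylamine or a guanidine would read on this amine nitrogen. Also open, going by these compounds, is whether a longer chain arranged as in compound 2 would keep a number near that of compound 2, 8.6 nM.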